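The source may hold more compounds than are shown below. What is called first, only, known or untested is meant among the compounds shown, and "the series" means these compounds.

Measured in a functional assay (mast cells) for inhibition, with Rattus norvegicus as the target; on this read-out higher numbers stand for an effect only at larger amounts of compound and lower numbers for an effect already at smaller amounts
Compound 1 `CCOc1ccc(N/N=C2\CC[C@H](C)n3c2ncc(C(=O)O)c3=O)cc1` gives 19200 nM
Compound 2 `CC1CC/C(=N\Nc2ccc([N+](=O)[O-])cc2)c2ncc(C(=O)O)c(=O)n21` gives 8900 nM
Compound 3 `CC1CCC(=NNc2ccccc2C(=O)O)c2ncc(C(=O)O)c(=O)n21` gives 569000 nM; 1100000 nM (2 entries)

Compound 2 at 8900 nM holds the lower of the two single numbers. Compound 1 lies nearest at 19200 nM, a gap beyond the usual scatter. Compound 3 has no single number, only (the several entries of compound 3 in this assay, 569000 nM; 1100000 nM (2 entries)), and these entries lie far higher.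

Next in view is compound 4 `CNC(=O)c1ccc(N/N=C2\CCC(C)n3c2ncc(C(=O)O)c3=O)cc1`, which differs from compound 2 by one change methylcarbamoyl in place of nitro on an aromatic carbon, para to a large group. Among the measured compounds shown here, no measured pair isolates this change in this assay, so the expectation is loose. Compound 1 at 19200 nM points to a modest shift as the likelier outcome, while compound 3 at 569000 nM; 1100000 nM (2 entries) shows how high numbers can run in this series. The expected change is a 2.2-fold higher number from compound 2 to compound 4 (0.35 log units; beyond the scatter), a modest move towards a higher number. For compound 4 the estimated value is 20000 nM, with an expected range from 6000 nM to 80000 nM.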

Compound 4, half-maximal effective concentration: 100000 nM
Compound 4: the middle estimate sits 5.0-fold (0.70 log units) below what was measured; measured number above the stated range.
By their numbers in this assay, from the lowest: compound 2; then compound 1; then compound 4.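

In this assay, the place para to a large group on the aromatic ring of carbon only is sensitive to its substituent: methylcarbamoyl in place of nitro gives an 11-fold higher number from compound 2 to compound 4 (1.05 log units; beyond the scatter). Among the compounds shown here, this is the first step that isolates a single change, and it shows that this exchange alone can move the number substantially, not just by a modest amount. Nothing measured on these compounds bears on why the step is this large.

On these data alone, with one step at this place, it remains open whether the higher number goes with the entry of methylcarbamoyl, with its amide hydrogen, or with the departure of nitro. A nitrile, an amine or a dimethylcarbamoyl group on the same carbon would help to separate these readings.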